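The source may hold more compounds than are shown below. What is called first, only, known or untested is meant among the compounds shown, and "the series" means these compounds.

Working notes on the series.

Compound 1 `FC(F)(F)c1ccccc1-c1nc(NCc2ccccc2)c2ccccc2n1` gives, in an assay on a protein complex for inhibition of ubiquitin carboxyl-terminal hydrolase 1/WD repeat-containing protein 48 (Homo sapiens), read by fluorescence (on this read-out higher numbers stand for weaker inhibition and lower numbers for stronger inhibition), 3100 nM. Compound 2 `Fc1ccc(CNc2nc(-c3ccccc3C(F)(F)F)nc3ccccc23)cc1` carries the change fluoro in place of hydrogen on an aromatic carbon and gives in this assay 3400 nM; the step of a 1.1-fold higher number from compound 1 to compound 2 (0.04 log units; within the scatter).

Compound 3 `Cc1cnc(-c2ccccc2C(C)C)nc1NCc1ccc(-c2cccnc2)cc1` sits on a different core; how its core differs from that of compound 1 is not broken down here. In this assay compound 3 gives 70 nM, the lowest of the three numbers and beyond the scatter from both others.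

Compound 4 `Cc1cnc(-c2ccccc2C(C)C)nc1NCc1ccc(-c2ccc(F)nc2)cc1`, not yet measured, differs from compound 3 by fluoro in place of hydrogen on an aromatic carbon. This is the same kind of change as from compound 1 to compound 2, not the same: there the place was a six-membered aromatic ring of carbon only, para to a large group; here it is a six-membered aromatic ring with one nitrogen, next to the ring nitrogen, para to a large group. Among the measured compounds shown here, because the only measured instance, a 1.1-fold higher number from compound 1 to compound 2 (0.04 log units; within the scatter), lay within the scatter, the step of a 1.1-fold higher number from compound 3 to compound 4 (0.03 log units; within the scatter) in this assay is expected to be small as well. Compound 4 is therefore estimated at 75 nM, in the range 35 nM to 160 nM.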

Compound 4, half-maximal inhibitory concentration: 80 nM
Compound 4: the middle estimate sits 1.1-fold (0.03 log units) below what was measured; the measured number falls inside the stated range.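

In this assay, pyridin-3-yl to 6-fluoropyridin-3-yl gives a 1.1-fold higher number from compound 3 to compound 4 (0.06 log units; within the scatter). Set beside the earlier case, fluoro in place of hydrogen on an aromatic carbon gives steps on the two cores that cannot be told apart: the same change on two cores in this assay, a 1.1-fold higher number (0.04 log units; within the scatter) from compound 1 to compound 2 and a 1.1-fold higher number (0.06 log units; within the scatter) from compound 3 to compound 4, 1.0-fold (0.02 log units) apart, within the scatter of two such steps. Among the compounds shown here, this shows only that the change left the number within the scatter in both instances, which lie at different places on different rings; it does not show that the change would behave alike at other places or on other cores, and two such steps cannot separate the part played by the core from that of the place.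

Still open, going by these compounds, is whether an amine, a methoxy group or a nitrile in place of the fluoro of compound 4 would move the number. Also open, on these data alone, is how the pyridin-3-yl group would read on the core of compound 1.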